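A few compounds are considered here, and "the series" means these few. Any claim that something is new, unique, unknown or untested is made for them only; others in the source may bear on it.

In a functional assay on HeLa cells (Homo sapiens) for cytotoxicity, read by MTT assay, with a stated time of 72 h (on this read-out higher numbers stand for weaker inhibition and lower numbers for stronger inhibition), compound 1 `COc1ccc(/C=C/C(=O)OCC(=O)Nc2ccc(Cl)cc2)cc1OC` gives 45400 nM. Compound 3 `COc1ccc(NC(=O)COC(=O)/C=C/c2ccc(O)c(O)c2)cc1` returns only a limit of this assay, namely > 200000 nM. Compound 2 `COCOc1cc(/C=C/C(=O)OCC(=O)Nc2nccs2)ccc1OCc1ccccc1` likewise returns only a limit in this assay, > 200000 nM. Compound 2 thus stands at the limit of > 200000 nM in this assay, at which 2 of the 3 values shown sit, with no number of its own. Compound 4 `COCOc1cc(/C=C/C(=O)OCC(=O)Nc2ccc(OC)cc2)ccc1OCc1ccccc1` differs from compound 2 by 4-methoxyphenyl in place of 1,3-thiazol-2-yl on an amide-type nitrogen. Among the measured compounds shown here, no measured pair shows this change on its own, and compound 3, which also carries the 4-methoxyphenyl amide, sits at its limit of > 200000 nM. The step of an at least 1.5-fold lower number from compound 2 to compound 4 (0.18 log units; that floor lies within the scatter) is expected to be small, not clearly beyond the scatter. For compound 4 in this assay an inhibitory concentration of 130000 nM is estimated, within 40000 nM to 400000 nM, and a limit instead of a number is expected to be likely.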

Compound 4, half-maximal inhibitory concentration: 155000 nM
Estimate against measurement, compound 4: 1.2-fold (0.08 log units) below; low and high end bracket the measured number.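

In this assay, 4-methoxyphenyl in place of 1,3-thiazol-2-yl on the amide-type nitrogen gives an at least 1.2-fold lower number from compound 2 to compound 4 (0.11 log units; that floor lies within the scatter) and so shows no change clearly beyond the scatter. That step is only a floor, since compound 2 holds a limit of the assay rather than a number: the limit of > 200000 nM in this assay, at which 2 of the 4 values shown sit. Among the compounds shown here, compound 4 nonetheless gives this position a measured number for the first time. On these data alone, how far compound 2 truly lies from compound 4 stays open. Also open, as far as these compounds go, is how a pyridine ring or a longer alkyl chain on that nitrogen would read.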